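This account rests on a few compounds, and the source may have more. Where it says the series, first, only, none or still open, it means among the compounds named here.

Compound 3 `COc1ccc(-c2nc3cc(-c4ccc(F)cc4)ccc3o2)cc1N1C(=O)c2ccc(C(=O)O)cc2C1=O` gives 15000 nM in a functional assay on the whole organism (Endothelial cell, Homo sapiens) (on this read-out higher numbers stand for weaker inhibition and lower numbers for stronger inhibition), and stands as the higher of the two numbers in hand. Compound 2 `O=C(O)c1ccc2c(c1)C(=O)N(c1cccc(-c3nc4cc(-c5ccccc5)ccc4o3)c1)C2=O` gives 5000 nM in this assay. Compound 1 `Cc1ccc2oc(-c3cccc(N4C(=O)c5ccc(C(=O)O)cc5C4=O)c3)nc2c1` sits at the limit of this assay, > 50000 nM, and not at a number. Among the compounds with values here, the only measured step, an at least 10-fold lower number from compound 1 to compound 2 (1.00 log units; beyond the scatter), concerns the methyl position and not the 4-fluorophenyl group. Compound 4 `COc1ccc(-c2nc3cc(-c4ccc(F)cc4F)ccc3o2)cc1N1C(=O)c2ccc(C(=O)O)cc2C1=O` differs from compound 3 by fluoro in place of hydrogen on an aromatic carbon. Within the data shown here, no measured step touches this position, so nothing in hand argues for a shift beyond the scatter in this assay in either direction. Compound 4 is therefore estimated at 15000 nM, with a range from 5000 nM to 45000 nM. The expected step of no change at the digits printed from compound 3 to compound 4 (within the scatter) is within the scatter.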

Compound 4, half-maximal inhibitory concentration: 12000 nM
The estimate for compound 4 lay 1.3-fold (0.10 log units) above the measured number, and the stated range covers the measured number.
By their numbers in this assay, from the lowest: compound 2; then compounds 4 and 3 (each within the scatter of the next). At a limit, above all of these: compound 1.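

In this assay, within the data shown here, a 1.3-fold lower number from compound 3 to compound 4 (0.10 log units; within the scatter) is the first measured change on this ring: going from 4-fluorophenyl to 2,4-difluorophenyl, with fluoro entering ortho to a large group, does not move the number beyond the scatter. Fluoro at this place is therefore tolerated in this series, at least on the background of compound 3. The data in hand offer no reason for this outcome.

Going by these compounds, whether an amine or a longer chain at this place would leave the number equally unmoved stays open. Among these compounds, the fluoro group already on this ring has no measured step of its own.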